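The compounds below may be only part of what the source reports. "The series", "measured", "known", "first", "only" and "open" are said of these compounds alone.

Compound 1 `O=C(CN1CCN(C(=O)c2ccc(F)cc2)CC1)N1CCN(CCCc2c[nH]c3ccccc23)CC1` gives 188000 nM
Compound 2 `O=C(CN1CCN(C(=O)c2ccc(Cl)cc2)CC1)N1CCN(CCCc2c[nH]c3ccc(F)cc23)CC1` gives 125000 nM

Both values come from an ADME assay on SH-SY5Y cells (Homo sapiens) for cytotoxicity, read by MTT assay, with a stated time of 72 h (on this read-out lower numbers stand for stronger inhibition and higher numbers for weaker inhibition), and lie within the scatter of each other, so compound 2 stands level with compound 1 on these numbers. Among the measured compounds shown here, the series offers no step between measured compounds that differ in one place. Compound 3 `O=C(CN1CCN(C(=O)c2cccc(Br)c2)CC1)N1CCN(CCCc2c[nH]c3ccc(F)cc23)CC1` has not yet been measured. It differs from compound 2 by 3-bromophenyl in place of 4-chlorophenyl on a carbonyl carbon as 3-bromophenyl in place of 4-chlorophenyl on a carbonyl carbon. For the measured compounds named here, with compound 1 at 188000 nM and compound 2 at 125000 nM as the only guides, no change beyond the scatter is expected in this assay from this replacement. The expected 1.0-fold lower number from compound 2 to compound 3 (0.02 log units; within the scatter) is small and stays within the scatter. For compound 3 the estimated value is 120000 nM with 60000 nM to 240000 nM as the expected range.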

Compound 3, half-maximal inhibitory concentration: 71600 nM
Compound 3: the middle estimate sits 1.7-fold (0.22 log units) above what was measured; low and high end bracket the measured number.
By their numbers in this assay, from the lowest: compounds 3, 2 and 1 (each within the scatter of the next, the first and the last beyond it).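

In this assay the series now has its first step between compounds that differ in one place: a 1.7-fold lower number from compound 2 to compound 3 (0.24 log units; within the scatter) for the replacement on a carbonyl carbon. At this position, 3-bromophenyl in place of 4-chlorophenyl gives no change that can be told from the scatter, although the halogen and its location on the ring change together, so neither can be read alone. Nothing on hand bears on the origin of this result.

Open, going by these compounds, is whether 4-bromophenyl or 3-chlorophenyl would separate those two features, and whether an amine or a carboxylic acid on this ring would give a step beyond the scatter. Compound 1 and compound 2 differ in more than one place, so each of their differences also remains unread on its own.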